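This account rests on a few compounds, and the source may have more. Where it says the series, first, only, none or still open, it means among the compounds named here.

In a physicochemical assay for solubility, read by HPLC, using the shake flask method, measured as kinetic solubility, with a stated time of 20 h, at pH 6.5, tested at 200 uM (on this read-out higher numbers stand for higher solubility and lower numbers for lower solubility), compound 1 (`C[C@@H](CO)NS(=O)(=O)c1cccc(-c2ccc3nccc(-c4ccncc4)c3n2)c1`) gives 50000 nM. Compound 3 (`CS(=O)(=O)Nc1ccc2nccc(-c3ccncc3)c2n1`) gives 90000 nM, within the usual scatter of compound 1. Compound 2 (`CS(=O)(=O)c1cccc(-c2ccc3nccc(N4CCNCC4)c3n2)c1`) gives 165000 nM, higher than compound 1 and beyond that scatter. Compound 4 (`O=S(=O)(c1cccc(-c2ccc3nccc(-c4ccncc4)c3n2)c1)N1CC[C@H](O)C1`) keeps the shared core of compound 1 but has 3-hydroxypyrrolidin-1-yl in place of (1-(hydroxymethyl)ethyl)amino on a sulfonyl sulfur. Within the data shown here, no two measured compounds differ in just one place, so the data give no direct guide to this change. The estimated 1.3-fold lower number from compound 1 to compound 4 (0.10 log units; within the scatter) is expected to stay within the usual scatter of this assay. The expected value for compound 4 is 40000 nM, with an estimated range of 12000 nM to 110000 nM.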

Compound 4, solubility: 20000 nM
Beside the measured number, compound 4's estimate is 2.0-fold (0.30 log units) above it, within the range that was stated.
By their numbers in this assay, from the lowest: compound 4; then compounds 1, 3 and 2 (each within the scatter of the next, the first and the last beyond it).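

In this assay, among these compounds, this is the first comparison of two compounds that differ in one place. Replacing the open chain (1-(hydroxymethyl)ethyl)amino with the ring 3-hydroxypyrrolidin-1-yl on a sulfonyl sulfur gives a 2.5-fold lower number from compound 1 to compound 4 (0.40 log units; beyond the scatter), so the group held on this sulfur can shift the read-out beyond the usual scatter. No measurement shown here explains this step. Going by these compounds, it remains open whether the ring itself or the different hydrogen-bond donor count goes with the drop, and how a plain dimethylamino group or morpholin-4-yl on the same sulfur would compare.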